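The source may hold more compounds than are shown below. What is called first, only, known or untested is meant among the compounds shown, and "the series" means these compounds.

In a functional assay on MOLT-4 cells (Homo sapiens) for inhibition (on this read-out higher numbers stand for weaker inhibition and lower numbers for stronger inhibition), compound 1, with the structure `CCC(C)C1NC(=O)N(C2CCCCC2)C1=O`, gives > 200000 nM; this is a limit of the assay, not a measured number. Compound 2, with the structure `O=C1NC(c2ccccc2)C(=O)N1Cc1ccccc1`, gives > 200000 nM in this assay, again a limit and not a number. Both compounds therefore sit at the same boundary, (the limit of > 200000 nM in this assay, at which 2 of the 2 values shown sit), so the numbers shown do not separate one from the other, and compound 1 cannot be placed higher or lower than compound 2.

Compound 3, with the structure `CC(C)C1NC(=O)N(C2CCCCC2)C1=O`, is the next compound to be measured in this assay. It differs from compound 1 in a single place: hydrogen in place of methyl on a saturated chain carbon, two bonds along the chain from a saturated ring carbon. For the measured compounds named here, no step between two measured compounds is available to show how large a change of this kind is. The expected step is a step that the limit leaves unreadable from compound 1 to compound 3, a change no larger than the usual scatter and in no particular direction. Compound 3 is therefore estimated at 300000 nM, within a range from 100000 nM to 2000000 nM, with a strong chance that the assay again reports only a limit.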

Compound 3, half-maximal inhibitory concentration: > 200000 nM
Compound 3: no number, only a limit; the forecaster's own chance of this, stated with the estimate: 85%; the middle value lies beyond the limit too.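

Compound 1 and compound 3 both return only a limit of the assay in this assay, not a number, so no step between them can be read: the limit of > 200000 nM in this assay, at which 3 of the 3 values shown sit.

The compounds shown leave open how strongly any of them inhibits, and whether going from sec-butyl to isopropyl changes inhibition at all.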